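Chain variation on the compound 1 core

A few compounds are considered here, and "the series" means these few. Any claim that something is new, unique, unknown or untested is made for them only; others in the source may bear on it.

Measured in a functional assay on MCF7 cells (Homo sapiens) for antiproliferative activity, read by MTT assay; on this read-out higher numbers stand for weaker inhibition and lower numbers for stronger inhibition:
- compound 1 `CCCCCCCCCCCCCCCC1(O)CC(=O)c2c(O)cc(O)cc2O1`: 17500 nM
- compound 2 `CCCCCCCCCCCCCCCCCCCC1(O)CC(=O)c2c(O)cc(O)cc2O1`: > 67200 nM (a limit)
- compound 3 `CCCCCCCCCCCCCCCC1(O)CC(=O)c2c(O)cc(OCOC)cc2O1`: > 67200 nM (a limit)

For the measured compounds named here, compound 1 holds the only actual number in the set, as the other two values are limits. The next compound is compound 4 `CCCCC/C=C\C/C=C\CCCCCCCC1(O)CC(=O)c2c(O)cc(O)cc2O1`, where the chain changes: deca-1,4-dien-1-yl in place of octyl on a saturated chain carbon, seven bonds along the chain from a saturated ring carbon. The closest measured change is butyl in place of hydrogen on a saturated chain carbon, which gave an at least 3.8-fold higher number from compound 1 to compound 2 (0.58 log units; beyond the scatter). This step is beyond the scatter, and it is also a change in the chain. The methoxymethyl change on an oxygen on an aromatic ring gave an at least 3.8-fold higher number from compound 1 to compound 3 (0.58 log units; beyond the scatter), but it lies away from the chain and bears only weakly here. Going by the values given here, no measured step covers double bonds in the chain, so the direction rests on compound 2 alone. A moderate move towards weaker inhibition is expected, smaller than the compound 2 step, with a 1.6-fold higher number from compound 1 to compound 4 (0.20 log units; within the scatter) as the expected change. For compound 4 the estimated value is 28000 nM, with an expected range of 11000 nM to 65000 nM.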

Compound 4, half-maximal inhibitory concentration: 17500 nM
Compound 4: middle estimate off by 1.6-fold (0.20 log units), on the high side; measured number inside the range.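

In this assay, deca-1,4-dien-1-yl in place of octyl on a saturated chain carbon, seven bonds along the chain from a saturated ring carbon, gives no change at the digits printed from compound 1 to compound 4 (within the scatter). For the compounds shown here, the chain of compound 1 therefore accepts this change, including its 2 double bonds, with no loss at this read-out, whereas the only earlier chain step gave an at least 3.8-fold higher number from compound 1 to compound 2 (0.58 log units; beyond the scatter). Changing the chain does not in itself weaken inhibition in this pair, and compound 2 is the listed case that goes the other way.

The size of the steps to compound 2 and compound 3 stays open, as each ends on a limit and not on a number: the limit of > 67200 nM in this assay, at which 2 of the 4 values shown sit. The compounds shown also do not separate the effect of the double bonds from that of the added carbons, and a chain ending in a carboxylic acid or an amine remains untested in this series.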